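The source may hold more compounds than are shown below. What is called first, only, known or untested is meant among the compounds shown, and "the series" means these compounds.

Measured in a functional assay on A549 cells (Homo sapiens) for cytotoxicity, read by sulforhodamine B assay; on this read-out higher numbers stand for weaker inhibition and lower numbers for stronger inhibition:
Compound 1 `CN1CCCN(c2nc(-c3ccccc3)nc3ccccc23)CC1`: 24.1 ug/mL
Compound 2 `CNc1nc(-c2ccccc2)nc2ccccc12`: 29.3 ug/mL

For the measured compounds named here, only these two compounds have numbers so far. Their values lie within the scatter of each other, so compound 2 cannot be ranked against compound 1. Compound 3 `CN(C)CCN(C)c1nc(-c2ccccc2)nc2ccccc12` is compound 2 with a single change: 2-(dimethylamino)ethyl in place of hydrogen on a nitrogen on an aromatic ring. In words, 2-(dimethylamino)ethyl takes the place of hydrogen on a nitrogen on an aromatic ring.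

Going by the values given here, one measured step bears on this, and only indirectly: a 1.2-fold higher number from compound 1 to compound 2 (0.08 log units; within the scatter). That step puts methylamino in place of 4-methyl-1,4-diazepan-1-yl on an aromatic carbon, and it stays within the scatter. It is thin evidence, and neither measured compound carries the 2-(dimethylamino)ethyl group. In this assay, therefore, no step beyond the scatter is expected, and neither direction can be favoured. The estimate is a 1.1-fold lower number from compound 2 to compound 3 (0.05 log units; within the scatter), an expected shift that remains small. For compound 3 the expected value is 26 ug/mL, with an estimated range of 11 ug/mL to 50 ug/mL.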

Compound 3, half-maximal inhibitory concentration: 28.1 ug/mL
Beside the measured number, compound 3's estimate is 1.1-fold (0.03 log units) below it, within the range that was stated.
By their numbers in this assay, from the lowest: compounds 1, 3 and 2 (each within the scatter of the next).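

At the nitrogen on an aromatic ring whose other neighbours are an aromatic carbon and a saturated chain carbon, compound 2 carries a hydrogen and compound 3 carries 2-(dimethylamino)ethyl, a group of 5 heavy atoms with no ring. In this assay this exchange gives a 1.0-fold lower number from compound 2 to compound 3 (0.02 log units; within the scatter), so this position accepts the added chain without a step beyond the scatter, and the two compounds cannot be ranked. The open (2-(dimethylamino)ethyl)(methyl)amino group likewise cannot be ranked against the 4-methyl-1,4-diazepan-1-yl ring, with a 1.2-fold higher number from compound 1 to compound 3 (0.07 log units; within the scatter), and no measurement at hand explains why these groups on the aromatic carbon fall so close together.

Going by these compounds, what remains open is whether any group at this place would move the number beyond the scatter, for instance a longer chain or a carboxylic acid in place of 2-(dimethylamino)ethyl on that nitrogen. On these data alone, it is also open whether a morpholine or a piperazine ring on the aromatic carbon would stay as close to these three compounds.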